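Chain extension at the aromatic carbon, all at the limit

This account rests on a few compounds, and the source may have more. Where it says the series, first, only, none or still open, it means among the compounds named here.

Compound 2 `Cc1cn([C@@H]2O[C@@H]3COP(=O)(O)O[C@H]3[C@H]2O)c(=O)nc1N` stands only at a limit in a functional assay on L1210 cells (Mus musculus) for cytotoxicity; a higher number here means a weaker inhibitor, a lower number a stronger inhibitor: compound 2 gives > 200 ug/mL, which is a limit of the assay. Compound 1 `CCCCCCCCc1cn([C@@H]2O[C@@H]3COP(=O)(O)O[C@H]3[C@H]2O)c(=O)nc1N` likewise gives > 200 ug/mL, a limit. Compound 3 `CCCCCc1cn([C@@H]2O[C@@H]3CO[PH](O)(O)O[C@H]3[C@H]2O)c(=O)nc1N` gives > 200 ug/mL, again a limit. All three values share (the limit of > 200 ug/mL in this assay, at which 3 of the 3 values shown sit). Among the compounds with values here, the one measured step, a step that the two limits leave unreadable from compound 1 to compound 2, therefore has no readable size. Compound 4 `CCCCCCc1cn([C@@H]2O[C@@H]3COP(=O)(O)O[C@H]3[C@H]2O)c(=O)nc1N` differs from compound 2 by pentyl in place of hydrogen on a saturated chain carbon bound to an aromatic carbon. Within the data shown here, no measured step gives a readable size for this change; the data show only that heptyl, methyl and pentyl all left the value at the limit. Compound 4 is therefore expected to remain at the limit, with an expected step of a number no higher from compound 2 to compound 4 (the limit leaves the size open). The estimate for compound 4 in this assay is 200 ug/mL, ranging from 60 ug/mL to 600 ug/mL.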

Compound 4, concentration for 50% inhibition: > 200 ug/mL
Compound 4 was reported as a limit; the forecaster's own chance of this, stated with the estimate: 85%; the middle value sits exactly at the limit.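

In this assay compound 4 gives > 200 ug/mL, a limit. The steps to compound 4 from compound 1 and compound 2 cannot be read: the limit of > 200 ug/mL in this assay, at which 4 of the 4 values shown sit. The compounds shown leave open whether any chain length gives a value inside the measurable range.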